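Removing the Fluoro from Compound 2 on a Benzothiazole-Linked Scaffold

The source may hold more compounds than are shown below. What is called first, only, known or untested is meant among the compounds shown, and "the series" means these compounds.

Of the compounds shown here, three have been measured in a functional assay on HeLa cells (Homo sapiens) for antiproliferative activity, read by MTT assay, with a stated time of 48 h; a lower number here means a stronger inhibitor, a higher number a weaker inhibitor. Compound 1 `Cc1ccc2nc(Nc3nc(Nc4ccc(S(C)(=O)=O)cc4)ncc3F)sc2c1` gives 17200 nM in this assay. Compound 2 `COc1ccc2nc(Nc3nc(Nc4ccc(S(N)(=O)=O)cc4)ncc3F)sc2c1` gives 13000 nM in this assay, a value within the scatter of that of compound 1; how the core of compound 2 differs from the core of compound 1 is not broken down here. Compound 3 `Cc1ccc2nc(Nc3ccnc(Nc4ccc(S(C)(=O)=O)cc4)n3)sc2c1` gives 2300 nM in this assay.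

Compound 3 is related to compound 1 by a single change, (hydrogen in place of fluoro on an aromatic carbon). This change made a step of a 7.5-fold lower number from compound 1 to compound 3 (0.87 log units; beyond the scatter), which is beyond the scatter and is described as modest.

Compound 4 `COc1ccc2nc(Nc3ccnc(Nc4ccc(S(N)(=O)=O)cc4)n3)sc2c1` has not yet been measured. It stands to compound 2 as compound 3 stands to compound 1: the change is hydrogen in place of fluoro on an aromatic carbon, and the place is described in the same words, so it is the same change. It occurs only twice among the compounds shown, so the expectation rests on a single measured pair. Within the data shown here, compound 4 is expected to show a step of a 7.2-fold lower number from compound 2 to compound 4 (0.86 log units; beyond the scatter) in this assay, close to the one seen from compound 1 to compound 3, because compound 2 starts from 13000 nM and the same change gave a 7.5-fold lower number from compound 1 to compound 3 (0.87 log units; beyond the scatter). Compound 4 is therefore estimated at 1800 nM in this assay, with a likely range from 600 nM to 6000 nM.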

Compound 4, half-maximal inhibitory concentration: 1730 nM
Beside the measured number, compound 4's estimate is 1.0-fold (0.02 log units) above it; the measured number falls inside the stated range.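

In this assay, hydrogen in place of fluoro on an aromatic carbon gave a 7.5-fold lower number from compound 2 to compound 4 (0.88 log units; beyond the scatter), and this step sits close to the one already seen on the other core: the same change on two cores in this assay, a 7.5-fold lower number (0.87 log units; beyond the scatter) from compound 1 to compound 3 and a 7.5-fold lower number (0.88 log units; beyond the scatter) from compound 2 to compound 4, 1.0-fold (0.00 log units) apart, within the scatter of two such steps. Within these four compounds, then, the change carried from the core of compound 1 to the core of compound 2 with its size intact, even though those two cores are not the same, and in both pairs the compound with hydrogen gave the lower number. This does not show that the step would hold on any further core or in another kind of assay, since it rests on just two pairs read in one antiproliferative test on one cell line, and it says nothing about why removing the fluoro lowers the number.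

The compounds shown leave open whether a chloro, a methyl or a nitrile on that same aromatic carbon would give a number closer to the fluoro compounds or to the hydrogen compounds. They also leave open how the methoxy and the sulfonamide each act on their own, since these two groups change together between the cores and no compound shown separates them.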